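An Aryl Group Added to the Tightest Sigma Binder

A few compounds are considered here, and "the series" means these few. Any claim that something is new, unique, unknown or untested is made for them only; others in the source may bear on it.

Of the compounds shown here, two have so far been measured in an assay on membranes from brain for displacement of a labelled ligand from Sigma non-opioid intracellular receptor 1 (Cavia porcellus), read by scintillation counting, with a stated time of 120 min; on this read-out lower numbers stand for stronger inhibition and higher numbers for weaker inhibition. Compound 1 `Cc1ccc(-c2scc3c2CCOC32CCN(Cc3ccccc3)CC2)cc1` gives 3.6 nM. Compound 2 `COC1Cc2cscc2C2(CCN(Cc3ccccc3)CC2)O1`, built on a different core, gives 0.22 nM in this assay, the lowest of the two numbers; compound 1 stands clearly higher, beyond the usual scatter.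

Compound 3 `COC1Cc2c(csc2-c2ccc(C)cc2)C2(CCN(Cc3ccccc3)CC2)O1` has not yet been measured. It differs from compound 2 in one place: 4-methylphenyl in place of hydrogen on an aromatic carbon. For the measured compounds named here, no measured pair differs only in this way, so the size of this step is not known from the data; compound 1 carries the same group on another core, and its value simply sits above that of compound 2. Compound 3 is expected to bind somewhat less tightly than compound 2, with a step of a 4.5-fold higher number from compound 2 to compound 3 (0.66 log units; beyond the scatter). The estimate for compound 3 in this assay is 1 nM, within a range from 0.2 nM to 6 nM.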

Compound 3, inhibition constant: 2 nM
Beside the measured number, compound 3's estimate is 2.0-fold (0.30 log units) below it, within the range that was stated.
By their numbers in this assay, from the lowest: compound 2; then compounds 3 and 1 (each within the scatter of the next).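

In this assay, for the compounds shown here, 4-methylphenyl in place of hydrogen on the aromatic carbon next to the ring sulfur gives a 9.1-fold higher number from compound 2 to compound 3 (0.96 log units; beyond the scatter), the first direct reading of this change: the position accepts the group, but binding is clearly weaker. Once that group is present, methoxy in place of hydrogen on a saturated ring carbon gives a 1.8-fold lower number from compound 1 to compound 3 (0.26 log units; within the scatter), which lies within the scatter, so this pair shows no clear effect of the methoxy group. No measurement shown here explains why the aryl group weakens binding.

Going by these compounds, whether a plain phenyl, a methyl or a chlorine at this position would give binding closer to that of compound 2 remains open. So does the effect of an amine or a carboxylic acid on the phenyl ring.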